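This account rests on a few compounds, and the source may have more. Where it says the series, first, only, none or still open, it means among the compounds named here.

Compound 1 `COc1ccc(/C=C/C(=O)c2ccccc2-c2cccc(F)c2)cc1`: 280 nM
Compound 2 `COc1ccc(/C=C/C(=O)c2ccccc2-c2ccc(F)nc2)cc1`: 930 nM
Compound 3 `COc1ccc(/C=C/C(=O)c2ccccc2-c2cccc(F)c2)cc1OC`: 330 nM

These three compounds have been measured in a functional assay on A549 cells (Homo sapiens) for antiproliferative activity, read by sulforhodamine B assay, with a stated time of 48 h; on this read-out lower numbers stand for stronger inhibition and higher numbers for weaker inhibition. Compound 1 and compound 2 differ by a single change, (6-fluoropyridin-3-yl in place of 3-fluorophenyl on an aromatic carbon), and that change gave a 3.3-fold higher number from compound 1 to compound 2 (0.52 log units; beyond the scatter). Compound 3 shares the core of compound 1 with one addition, (methoxy in place of hydrogen on an aromatic carbon), which gave a 1.2-fold higher number from compound 1 to compound 3 (0.07 log units; within the scatter). Compound 4 `COc1ccc(/C=C/C(=O)c2ccccc2-c2ccc(F)nc2)cc1OC` is not yet measured. It stands to compound 3 exactly as compound 2 stands to compound 1: the change is 6-fluoropyridin-3-yl in place of 3-fluorophenyl on an aromatic carbon, at the same place, so it is the same change. A step of similar size is expected, a 3.3-fold higher number from compound 3 to compound 4 (0.52 log units; beyond the scatter), because the earlier step was a 3.3-fold higher number from compound 1 to compound 2 (0.52 log units; beyond the scatter) and compound 3 sits at 330 nM. Compound 4 is therefore estimated at 1100 nM in this assay, with a likely range from 500 nM to 2500 nM.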

Compound 4, half-maximal inhibitory concentration: 1200 nM
The estimate for compound 4 lay 1.1-fold (0.04 log units) below the measured number, and the stated range covers the measured number.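

In this assay, putting 6-fluoropyridin-3-yl in place of 3-fluorophenyl on the core with the added methoxy gave a 3.6-fold higher number from compound 3 to compound 4 (0.56 log units; beyond the scatter), and this matches the step on the core without it: the same change on two cores in this assay, a 3.3-fold higher number (0.52 log units; beyond the scatter) from compound 1 to compound 2 and a 3.6-fold higher number (0.56 log units; beyond the scatter) from compound 3 to compound 4, 1.1-fold (0.04 log units) apart, within the scatter of two such steps. Adding the methoxy to the compound that already carries 6-fluoropyridin-3-yl gave a 1.3-fold higher number from compound 2 to compound 4 (0.11 log units; within the scatter), which also matches the earlier step: the same change on two cores in this assay, a 1.2-fold higher number (0.07 log units; within the scatter) from compound 1 to compound 3 and a 1.3-fold higher number (0.11 log units; within the scatter) from compound 2 to compound 4, 1.1-fold (0.04 log units) apart, within the scatter of two such steps. In these four compounds, each change therefore had a similar effect whether or not the other was present, but two cores that differ only by one methoxy cannot show that this holds on more distant cores, nor explain why the number changes.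

Going by these compounds, it remains open how a plain phenyl, or an aromatic ring carrying an amine or a carboxylic acid in place of the fluorine, would behave at this position.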